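The source may hold more compounds than are shown below. What is called first, only, known or untested is meant among the compounds shown, and "the series" means these compounds.

Measured so far:
Compound 1 `CNc1nc(-n2cc(-c3ccccn3)nn2)nc2c1ncn2[C@@H]1O[C@H](CO)[C@@H](O)[C@H]1O` gives 10.3 nM in an assay on CHO cells for displacement of a labelled ligand from adenosine receptor A3 (Homo sapiens); a higher number here means a weaker inhibitor, a lower number a stronger inhibitor.
Compound 2 `CCc1cn(-c2nc(NC)c3ncn([C@@H]4O[C@H](CO)[C@@H](O)[C@H]4O)c3n2)nn1` gives 13.8 nM in this assay.
Compound 3 `CCCCc1cn(-c2nc(NC)c3ncn([C@@H]4O[C@H](CO)[C@@H](O)[C@H]4O)c3n2)nn1` gives 11.7 nM in this assay.

Compound 3 holds the second highest of these three numbers; the step of a 1.1-fold higher number from compound 1 to compound 3 (0.06 log units; within the scatter) and the step of a 1.2-fold lower number from compound 2 to compound 3 (0.07 log units; within the scatter) both stay within the scatter, so none of the three can be set apart from another. Compound 4 `CNc1nc(-n2cc(CC3CCCCC3)nn2)nc2c1ncn2[C@@H]1O[C@H](CO)[C@@H](O)[C@H]1O` differs from compound 3 in one place: cyclohexyl in place of propyl on a saturated chain carbon bound to an aromatic carbon. Among the measured compounds shown here, the steps that bear on this change are those swapping the group on the same aromatic carbon: a 1.3-fold higher number from compound 1 to compound 2 (0.13 log units; within the scatter) and a 1.1-fold higher number from compound 1 to compound 3 (0.06 log units; within the scatter), plus a 1.2-fold lower number from compound 2 to compound 3 (0.07 log units; within the scatter), all within the scatter. Accordingly no step beyond the scatter is expected, a 1.2-fold lower number from compound 3 to compound 4 (0.07 log units; within the scatter). For compound 4 the estimate in this assay is 10 nM, with a range from 4 nM to 25 nM.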

Compound 4, inhibition constant: 21.3 nM
Compound 4: middle estimate off by 2.1-fold (0.33 log units), on the low side; low and high end bracket the measured number.
By their numbers in this assay, from the lowest: compounds 1, 3, 2 and 4 (each within the scatter of the next, the first and the last beyond it).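

In this assay, among the compounds shown here, cyclohexylmethyl on this aromatic carbon gives the first step beyond the scatter, a modest one, when it replaces pyridin-2-yl (a 2.1-fold higher number from compound 1 to compound 4 (0.32 log units; beyond the scatter)). Against the open chains it cannot be told apart (a 1.8-fold higher number from compound 3 to compound 4 (0.26 log units; within the scatter); a 1.5-fold higher number from compound 2 to compound 4 (0.19 log units; within the scatter)), so a saturated ring on the chain separates it only from the pyridin-2-yl compound. No measurement shown offers an explanation for this step.

As far as these compounds go, whether a chain longer than butyl would shift the number further remains open. So does the effect of an amine or a carboxylic acid at the end of the chain.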